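This account rests on a few compounds, and the source may have more. Where it says the series, first, only, none or still open, it means among the compounds named here.

Measured compounds:
- compound 1, `NC(=O)N(O)CC1=Cc2cc(OCc3ccccc3)ccc2OC1`: 380 nM
- compound 2, `NC(=S)N(O)CC1=Cc2cc(Oc3ccccc3)ccc2OC1`: 200 nM

Of the compounds shown here, two have been tested in an assay (Cavia porcellus) for inhibition of Polyunsaturated fatty acid 5-lipoxygenase (Homo sapiens); a higher number here means a weaker inhibitor, a lower number a stronger inhibitor. Compound 1 gives 380 nM in this assay, and compound 2 gives 200 nM. These two values lie within the usual scatter of repeated measurements, so the data do not separate one compound from the other; compound 2 simply stands with the smaller of two numbers that cannot be told apart with confidence.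

The next compound, compound 3, `CC(C)NC(=O)N(O)CC1=Cc2cc(Oc3ccccc3)ccc2OC1`, has not been measured. It differs from compound 2 in one place: a group of 6 heavy atoms (4 carbon, 1 nitrogen, 1 oxygen; no ring) in place of a group of 3 heavy atoms (1 carbon, 1 nitrogen, 1 sulfur; no ring), on an amine nitrogen. An isopropylcarbamoyl group thus enters on an amine nitrogen whose other neighbours are oxygen and a saturated chain carbon.

Among the measured compounds shown here, no step between measured compounds exists to show what such a change does here, so the expectation rests on the general closeness of the two measured values. Compound 3 is expected to give a number of the same order as compound 2, with a step of a 2.0-fold higher number from compound 2 to compound 3 (0.30 log units; within the scatter) that may be slightly weaker but not far beyond the scatter. For compound 3 the estimate is 400 nM, with a range from 150 nM to 1500 nM.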

Compound 3, half-maximal inhibitory concentration: 63 nM
For compound 3 the middle estimate is 6.3-fold (0.80 log units) above the measured one; measured number outside the range, below it.
By their numbers in this assay, from the lowest: compound 3; then compounds 2 and 1 (each within the scatter of the next).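

Among the compounds shown here, on the amine nitrogen whose other neighbours are oxygen and a saturated chain carbon, replacing the sulfur-bearing group of compound 2 with isopropylcarbamoyl gives a 3.2-fold lower number from compound 2 to compound 3 (0.50 log units; beyond the scatter) in this assay and is the first difference in this small set that stands clear of the scatter. The earlier pair could not show this, since its two values could not be told apart: here a larger group, with the heavy-atom count going up and the counted hydrogen-bond donors and acceptors staying the same, comes with a stronger inhibitor rather than a weaker one. Nothing available explains why the number fell.

This single step changes two things together, sulfur giving way to oxygen and an isopropyl group being added, so the compounds shown cannot say how much of the gain belongs to each. An isopropylthiocarbamoyl group on the same core would help separate the two, while methylcarbamoyl and tert-butylcarbamoyl groups would show how the result depends on the size of the added chain.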